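The source may hold more compounds than are shown below. What is called first, only, known or untested is meant among the compounds shown, and "the series" means these compounds.

Three measured compounds share one core and differ only in the pendant aromatic ring: compound 1 `Cc1nc(-c2cccnc2)sc1-c1nnc(-c2ccc(Br)cc2)o1`, compound 2 `Cc1nc(-c2cccnc2)sc1-c1nnc(-c2ccccc2Cl)o1` and compound 3 `Cc1nc(-c2cccnc2)sc1-c1nnc(-c2ccccc2)o1`. In an ADME assay on HeLa cells (Homo sapiens) for cytotoxicity, read by MTT assay (on this read-out higher numbers stand for lower toxicity in this test and lower numbers for higher toxicity in this test), compound 1 gives > 100 ug/mL, which is a limit of the assay and not a number. Compound 2 gives > 100 ug/mL in this assay, again only a limit. Compound 3 gives > 100 ug/mL in this assay, also a limit. Hence a step that the two limits leave unreadable from compound 1 to compound 2, a step that the two limits leave unreadable from compound 1 to compound 3 and a step that the two limits leave unreadable from compound 2 to compound 3; all three values sit at the limit of > 100 ug/mL in this assay, at which 3 of the 3 values shown sit. Compound 4 `Cc1cccc(-c2nnc(-c3sc(-c4cccnc4)nc3C)o2)c1` differs from compound 3 by methyl in place of hydrogen on an aromatic carbon. For the measured compounds named here, no measured step gives a readable size for such a change. Because every value stands at the limit of > 100 ug/mL in this assay, at which 3 of the 3 values shown sit, compound 4 is expected to stay at the limit, an estimated 150 ug/mL between 60 ug/mL and 400 ug/mL, an expected step that the limit leaves unreadable from compound 3 to compound 4 without readable size.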

Compound 4, half-maximal cytotoxic concentration: > 100 ug/mL
Compound 4 was reported as a limit (the forecaster's own chance of this, stated with the estimate: 85%); the middle value does not contradict the limit.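

In this assay no new step can be read between compound 4 and compound 1, compound 2 or compound 3, each result being only a limit: the limit of > 100 ug/mL in this assay, at which 4 of the 4 values shown sit.

The compounds shown leave open whether any change on the pendant ring alters cytotoxicity, and by how much.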